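A trifluoromethylphenyl group in place of methylphenyl on a ring nitrogen

The source may report more compounds than this note shows. Statements on the series, on what has been measured and on what is new or still open speak of the compounds shown alone.

Of the compounds shown here, three sharing one core have been measured in a functional assay on HepG2 cells (Homo sapiens) for inhibition, read by MTT assay, with a stated time of 72 h; a lower number here means a stronger inhibitor, a higher number a weaker inhibitor. Compound 1 `Cc1cccc(-n2cc(COc3cccc(NC(=O)Nc4ccc(Cl)c(C(F)(F)F)c4)c3)nn2)c1` gives 7270 nM, the highest of the three numbers. Compound 2 `CC(C)c1ccc(-n2cc(COc3cccc(NC(=O)Nc4ccc(Cl)c(C(F)(F)F)c4)c3)nn2)cc1` gives 2470 nM, and compound 3 `O=C(Nc1cccc(OCc2cn(-c3cccc(I)c3)nn2)c1)Nc1ccc(Cl)c(C(F)(F)F)c1` gives 4780 nM. Among the steps between them, a 2.9-fold lower number from compound 1 to compound 2 (0.47 log units; beyond the scatter), whereas a 1.5-fold lower number from compound 1 to compound 3 (0.18 log units; within the scatter), and a 1.9-fold higher number from compound 2 to compound 3 (0.29 log units; within the scatter).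

Compound 4 `O=C(Nc1cccc(OCc2cn(-c3ccccc3C(F)(F)F)nn2)c1)Nc1ccc(Cl)c(C(F)(F)F)c1` has not yet been measured. Relative to compound 1 the change is 2-(trifluoromethyl)phenyl in place of 3-methylphenyl on an aromatic nitrogen. Both measured steps that start from compound 1 alter the same aromatic group sitting on an aromatic nitrogen of a five-membered aromatic ring with 3 nitrogen, and neither moved the number far: one was a modest step beyond the scatter, the other stayed within it. A similar outcome is expected here, a small shift toward a lower number if any, estimated as a 1.5-fold lower number from compound 1 to compound 4 (0.16 log units; within the scatter). For compound 4 the expected value is therefore 5000 nM, with a range from 2000 nM to 12000 nM.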

Compound 4, half-maximal inhibitory concentration: 2320 nM
For compound 4 the middle estimate is 2.2-fold (0.33 log units) above the measured one, within the range that was stated.
By their numbers in this assay, from the lowest: compounds 4, 2, 3 and 1 (each within the scatter of the next, the first and the last beyond it).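

With 2-(trifluoromethyl)phenyl on the aromatic nitrogen, the number drops beyond the scatter from both of the weaker compounds: a 3.1-fold lower number from compound 1 to compound 4 (0.50 log units; beyond the scatter) and a 2.1-fold lower number from compound 3 to compound 4 (0.31 log units; beyond the scatter). This is the second group, after 4-isopropylphenyl, to give a step beyond the scatter from compound 1, and the two groups cannot be told apart, with a 1.1-fold lower number from compound 2 to compound 4 (0.03 log units; within the scatter), so a lower number here does not depend on one particular group on the phenyl ring. No supporting data are available that could explain this shift.

Among these compounds, all the groups at this position so far are substituted phenyl rings carrying a methyl, isopropyl, iodo or trifluoromethyl group. As far as these compounds go, it remains open how an amine or a carboxylic acid on that ring, or a longer chain in place of the ring, would change the number.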